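The source may hold more compounds than are shown below. What is called first, only, known or untested is meant among the compounds shown, and "the series" means these compounds.

Compound 2, `Nc1cc(N)c2nc(-c3ccccc3)c(NCc3ccc(Cl)c(Cl)c3)nc2c1`, is one of three compounds examined in a functional assay on A549 cells (Homo sapiens) for inhibition, read by sulforhodamine B assay, with a stated time of 48 h; a lower number here means a stronger inhibitor of growth, a higher number a weaker inhibitor of growth. In this assay compound 2 gives 27500 nM, the smaller of the two numbers recorded, although the gap to its neighbour lies within the scatter of repeated measurements. That neighbour, compound 1, `Nc1cc(N)c2nc(-c3ccccc3)c(Oc3ccc(Cl)c(Cl)c3)nc2c1`, gives 43700 nM in this assay, and on these two values the pair cannot be told apart. Compound 3, `CCOC(=O)[C@H](CCC(=O)O)NC(=O)c1ccc(Oc2nc3cc(N)cc(N)c3nc2-c2ccccc2)cc1`, returns only a limit in this assay, < 100000 nM, which is a boundary of the measurement rather than a number.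

Compound 4, `COc1ccc(CNc2nc3cc(N)cc(N)c3nc2-c2ccccc2)cc1`, has not yet been measured. It differs from compound 2 in one place: 4-methoxyphenyl in place of 3,4-dichlorophenyl on a saturated chain carbon bound to a nitrogen on an aromatic ring. Among the measured compounds shown here, no measured pair shows what such a swap does to growth inhibition here, so there is no basis for expecting a step in either direction beyond the scatter. Compound 4 is therefore expected to give about 35000 nM in this assay, with a likely range from 12000 nM to 100000 nM. That expectation corresponds to a step of a 1.3-fold higher number from compound 2 to compound 4 (0.10 log units; within the scatter).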

Compound 4, concentration for total growth inhibition: 60300 nM
Beside the measured number, compound 4's estimate is 1.7-fold (0.24 log units) below it; low and high end bracket the measured number.
By their numbers in this assay, from the lowest: compounds 2, 1 and 4 (each within the scatter of the next, the first and the last beyond it).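

Among the compounds shown here, this is the first step measured at this place, on a saturated chain carbon bound to a nitrogen on an aromatic ring: in this assay, 4-methoxyphenyl in place of 3,4-dichlorophenyl gives a 2.2-fold higher number from compound 2 to compound 4 (0.34 log units; beyond the scatter). The two groups have the same count of heavy atoms and each is one six-membered aromatic ring of carbon only, so what hangs on that ring can modestly shift growth inhibition here. Compound 3 gives only a limit, not a number, and offers no step at this place: the limit of < 100000 nM in this assay, at which 1 of the 4 values shown sits.

The swap removes two chlorines and adds a methoxy group in one move, so the compounds shown cannot separate the effect of one from the other. Going by these compounds, a plain benzyl group or a 4-chlorobenzyl group at this place would address that, and the effect of a longer chain between the nitrogen and the ring remains open.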